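Phenyl for Methyl on the Saturated Ring of Compound 3

The compounds below may be only part of what the source reports. "The series", "measured", "known", "first", "only" and "open" are said of these compounds alone.

compound 1 `O=C(O)C[C@H]1CCN1c1ccc(OCc2ccc(Cl)cc2Cl)cc1` — "not determined" (no result reported)
compound 2 `Cc1cccc(Oc2ccc(N3CCC[C@H]3CC(=O)O)cc2)c1` — "not determined" (no result reported)
compound 3 `Cc1ccccc1Cc1ccc(N2C[C@@H](C)C[C@H]2CC(=O)O)cc1` — 360 nM

In an assay on HEK293 cells for binding affinity to Free fatty acid receptor 1 (Homo sapiens), read by scintillation counting and radioligand binding, with a stated time of 1 h (a lower number here means a stronger inhibitor, a higher number a weaker inhibitor), compound 3 gives 360 nM. Among the measured compounds shown here, for compound 1 this assay records "not determined" (no result reported), and for compound 2 it records "not determined" (no result reported), so compound 3 holds the only number here and has nothing to stand against. Compound 4 `Cc1ccccc1Cc1ccc(N2C[C@@H](c3ccccc3)C[C@H]2CC(=O)O)cc1` differs from compound 3 in one place: phenyl in place of methyl on a saturated ring carbon. For the measured compounds named here, no step between measured compounds touches this change, so the data give no direction for it. The estimated step of a 1.2-fold lower number from compound 3 to compound 4 (0.08 log units; within the scatter) is expected to stay within the usual scatter, in either direction, with a wide range around it. The estimate for compound 4 is 300 nM, between 60 nM and 1500 nM.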

Compound 4, inhibition constant: > 25000 nM
Compound 4: a limit, no number; the forecaster's own chance of this, stated with the estimate: 5%; at least 83-fold (1.92 log units) between middle value and limit.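

In this assay, among the compounds shown here, phenyl in place of methyl on this saturated ring carbon gives an at least 69-fold higher number from compound 3 to compound 4 (1.84 log units; beyond the scatter), so the position, two ring bonds from the ring nitrogen, does not accept every carbon group, which the single methyl example could not show. The entry for compound 4 is a limit and not a number: the limit of > 25000 nM in this assay, at which 1 of the 4 values shown sits.

Going by these compounds, whether an ethyl, a cyclohexyl or a hydroxymethyl group on this carbon would stay near compound 3 remains open. So does what the same ring would give with only hydrogen there.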